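The source may hold more compounds than are shown below. What is called first, only, known or untested is meant among the compounds shown, and "the series" means these compounds.

Within the data shown here, compound 3, with the structure `COc1cc(Cl)cc(-c2nn(-c3cccc(NC(=O)Nc4cc(C(F)(F)F)cc(C(F)(F)F)c4)c3)cc2-c2ccncc2)c1`, is the strongest of the three compounds tested so far: in a functional assay on NCI-H226 cells (Homo sapiens) for inhibition, read by sulforhodamine B assay, with a stated time of 48 h, tested at 1 uM (a higher number here means a weaker effect of the compound at the concentration tested, a lower number a stronger effect), compound 3 gives 41%. Compound 1, `O=C(Nc1cccc(-n2cc(-c3ccncc3)c(-c3cc(O)cc(Cl)c3)n2)c1)Nc1ccc(Cl)c(C(F)(F)F)c1`, gives 96% in this assay, and compound 2, `O=C(Nc1cccc(-n2cc(-c3ccncc3)c(-c3cc(O)cc(Cl)c3)n2)c1)Nc1ccc(Cl)c(Cl)c1`, gives 96%; the step of no change at the digits printed from compound 1 to compound 2 (within the scatter) lies within the scatter. Both values of compound 1 and compound 2 stand well above that of compound 3, beyond the scatter.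

Compound 4, `COc1cc(Cl)cc(-c2nn(-c3cccc(NC(=O)Nc4cccc(C(F)(F)F)c4)c3)cc2-c2ccncc2)c1`, differs from compound 3 in one place: hydrogen in place of trifluoromethyl on an aromatic carbon, on the aryl carbon that is meta to a trifluoromethyl group. Among the measured compounds shown here, no measured step removes a trifluoromethyl outright; the only step on that aryl, no change at the digits printed from compound 1 to compound 2 (within the scatter), replaces one group by another and shows no change, so it gives only a weak guide. Compound 4 is therefore expected to lose some activity in this assay, by an estimated step of a number 24 percentage points higher from compound 3 to compound 4 (beyond the scatter), with wide uncertainty. Compound 4 is estimated at 65%, between 35% and 95%.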

Compound 4, a percentage reported as activity, at one concentration (the size of the read-out at that concentration, not a potency): 77%
For compound 4 the middle estimate is 12 percentage points below the measured one; the measured number falls inside the stated range.
By their numbers in this assay, from the lowest: compound 3; then compound 4; then compounds 1 and 2 (each within the scatter of the next).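

In this assay, hydrogen in place of trifluoromethyl on an aromatic carbon, meta to a trifluoromethyl group, gives a number 36 percentage points higher from compound 3 to compound 4 (beyond the scatter), so the read-out at the concentration tested depends on what occupies this place. Among these compounds, the only earlier step on this aryl ring, which exchanged one group for another, showed no change at the digits printed from compound 1 to compound 2 (within the scatter), whereas this step removes a group outright and shows that its absence is not tolerated without a large loss of effect. Nothing measured here accounts for the size of this step.

On these data alone, it remains open whether a chloro, a methyl or a nitrile at this place would keep the effect of compound 3 or fall towards that of compound 4. As far as these compounds go, it also remains open whether the step would be as large on a core carrying a hydroxyl rather than a methoxy group.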